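This account rests on a few compounds, and the source may have more. Where it says the series, first, only, none or still open, it means among the compounds named here.

Cytotoxicity across this series is followed in an ADME assay on THP-1 cells (Homo sapiens) for cytotoxicity, read by flow cytometry, with a stated time of 72 h; a lower number here means a stronger inhibitor, a higher number a weaker inhibitor. Compound 1 `N/C(=N\O)c1ccc(C2=C(S(=O)(=O)c3ccc(Nc4ccccc4/C(N)=N/O)cc3)CC(c3ccccc3)(c3ccccc3)O2)cc1` gives only a limit of the assay, > 50000 nM. Compound 3 `N/C(=N\O)c1ccc(/C=C/c2ccc(S(=O)(=O)C3=C(c4ccc(/C(N)=N/O)cc4)OC(c4ccccc4)(c4ccccc4)C3)cc2)cc1` likewise gives only a limit, > 10000 nM. The change between them is a group of 12 heavy atoms (9 carbon, 2 nitrogen, 1 oxygen; one six-membered aromatic ring of carbon only) in place of a group of 11 heavy atoms (7 carbon, 3 nitrogen, 1 oxygen; one six-membered aromatic ring of carbon only), on an aromatic carbon; the resulting step that the two limits leave unreadable from compound 1 to compound 3 cannot be sized, since compound 1 sits at the limit of > 50000 nM in this assay, at which 1 of the 3 values shown sits, and compound 3 sits at the limit of > 10000 nM in this assay, at which 1 of the 3 values shown sits.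

Among the compounds with values here, compound 2 `CC1(Cc2ccccc2)CC(S(=O)(=O)c2ccc(Nc3ccccc3/C(N)=N/O)cc2)=C(c2ccc(/C(N)=N/O)cc2)O1` is the one compound with a number: in this assay compound 2 gives 48400 nM. How the core of compound 2 differs from the core of compound 1 is not broken down here.

Compound 4 `CC1(Cc2ccccc2)CC(S(=O)(=O)c2ccc(/C=C/c3ccc(/C(N)=N/O)cc3)cc2)=C(c2ccc(/C(N)=N/O)cc2)O1` carries the same change on the core of compound 2, (a group of 12 heavy atoms (9 carbon, 2 nitrogen, 1 oxygen; one six-membered aromatic ring of carbon only) in place of a group of 11 heavy atoms (7 carbon, 3 nitrogen, 1 oxygen; one six-membered aromatic ring of carbon only), on an aromatic carbon), the change whose step between compound 1 and compound 3 stayed unreadable. With compound 2 already showing little cytotoxicity, only a small step is expected, a 1.1-fold lower number from compound 2 to compound 4 (0.03 log units; within the scatter), resting on compound 2 at 48400 nM and on the unsized a step that the two limits leave unreadable from compound 1 to compound 3. Compound 4 is accordingly estimated at 45000 nM, between 15000 nM and 120000 nM, with a fair chance that only a limit is reported.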

Compound 4, half-maximal inhibitory concentration: > 50000 nM
Compound 4 gave a limit, no number (the forecaster's own chance of this, stated with the estimate: 60%); middle value at least 1.1-fold (0.04 log units) away from the limit.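

In this assay, putting the group of 12 heavy atoms in place of the group of 11 heavy atoms on the core of compound 2 gives an at least 1.0-fold higher number from compound 2 to compound 4 (0.01 log units; that floor lies within the scatter). Compound 4 gives a limit, not a number: the limit of > 50000 nM in this assay, at which 2 of the 4 values shown sit.

Within the data shown here, on this core the change therefore brings no sign of a lower number, but the true size of the step remains unknown, and the step between compound 1 and compound 3 cannot be read either, so the two cores offer no sized steps to compare and do not show whether the change behaves alike on both.

Among the compounds shown, only these two groups occupy that aromatic carbon, so what an amine or a carboxylic acid there would give stays open. Also open, on these data alone, is how the two groups compare on a core where both give numbers rather than limits.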